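This account rests on a few compounds, and the source may have more. Where it says the series, first, only, none or still open, it means among the compounds named here.

Of the compounds shown here, two with related structures have been measured so far in a functional assay on the whole organism with Mus musculus as the target (on this read-out higher numbers stand for an effect only at larger amounts of compound and lower numbers for an effect already at smaller amounts), and both values are given here. Compound 1 `CN(C)C(=O)/C=C1\CCc2ccc(F)cc21` gives > 100 mg/kg as a limit of the assay and not as a number. Among the compounds with values here, compound 2 `O=C(/C=C1\CCc2cc(F)cc(F)c21)NC1CC1` gives 69 mg/kg as the only actual number available, so it has no measured neighbour to be ranked against. Compound 3 `NC(=O)/C=C1\CCc2cc(F)cc(F)c21` differs from compound 2 by one change (hydrogen in place of cyclopropyl on an amide-type nitrogen) and in words this is hydrogen in place of cyclopropyl on an amide-type nitrogen. Within the data shown here, no step between measured compounds bears on this change, so the expectation is loose. In this assay a moderate step toward effect at smaller amounts is expected, and the estimated 2.8-fold lower number from compound 2 to compound 3 (0.44 log units; beyond the scatter) gives its size. Compound 3 is expected at 25 mg/kg within an estimated range of 8 mg/kg to 75 mg/kg for now.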

Compound 3, dose for half-maximal effect: 44 mg/kg
Estimate against measurement, compound 3: 1.8-fold (0.25 log units) below, and the stated range covers the measured number.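

In this assay, within the data shown here, the amide-type nitrogen now gives the first readable step, a 1.6-fold lower number from compound 2 to compound 3 (0.20 log units; within the scatter), for hydrogen in place of cyclopropyl. At this position, therefore, the three-membered carbon ring can give way to a bare hydrogen with no difference that this read-out can resolve, and the effect seen with the cyclopropyl amide does not depend on that ring. Compound 1 differs from compound 2 and compound 3 in more than one place, and its value is a limit of the assay and not a number, so no step to it can be read: the limit of > 100 mg/kg in this assay, at which 1 of the 3 values shown sits.

Going by these compounds, whether a longer chain on the same nitrogen, or a chain ending in an amine or a carboxylic acid, would move the number beyond the scatter remains open. The pair also leaves open whether this tolerance for change at the nitrogen holds with other substituents on the shared core.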